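The source may report more compounds than this note shows. Statements on the series, on what has been measured and on what is new or still open speak of the compounds shown alone.

Measured so far in an assay on isolated protein for inhibition of Nitric oxide synthase, inducible (Homo sapiens), read by scintillation counting, with a stated time of 30 min, tested at 50 uM; on this read-out lower numbers stand for less inhibition and higher numbers for more inhibition at the one concentration tested (going by the name of the read-out):
- compound 1 `CC(=O)N1N=C(c2cc(Cl)ccc2N)SC1(C)C`: 72.8%
- compound 2 `CCC(=O)N1N=C(c2cc(Cl)ccc2N)SC1(C)C`: 1.07%
- compound 3 `CCCC(=O)N1N=C(c2cc(Cl)ccc2N)SC1(C)C`: 66.2%

Compound 3 stands second highest of the three numbers. Its nearest neighbour is compound 1: the step of a number 6.6 percentage points lower from compound 1 to compound 3 (within the scatter) lies within the scatter, so the two are not ordered. Its furthest is compound 2: the step of a number 65.1 percentage points higher from compound 2 to compound 3 (beyond the scatter) is large and beyond the scatter.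

Compound 4 `CCCCC(=O)N1N=C(c2cc(Cl)ccc2N)SC1(C)C` differs from compound 3 by one change: methyl in place of hydrogen on a saturated chain carbon, three bonds along the chain from a carbonyl carbon.

Within the data shown here, the steps that bear on it are the three chain extensions already measured. Adding one carbon to the chain gave a number 71.7 percentage points lower from compound 1 to compound 2 (beyond the scatter), a large fall, and adding one more gave a number 65.1 percentage points higher from compound 2 to compound 3 (beyond the scatter), a large rise, while the two-carbon extension from compound 1 to compound 3 gave only a number 6.6 percentage points lower from compound 1 to compound 3 (within the scatter). Single-carbon extensions have therefore swung this assay by large amounts in both directions, and no basis exists for choosing a direction for the next one. The expectation for compound 4 is a step of uncertain sign, estimated as a number 26.2 percentage points lower from compound 3 to compound 4 (beyond the scatter), with a wide range.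

Compound 4 is estimated at 40% in this assay, with a range from 3% to 80%.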

Compound 4, a percentage reported as inhibition, at one concentration (the size of the read-out at that concentration, not a potency): 12.6%
Compound 4: middle estimate off by 27.4 percentage points, on the high side; the measured number falls inside the stated range.
By their numbers in this assay, from the lowest: compound 2; then compound 4; then compounds 3 and 1 (each within the scatter of the next).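

In this assay, methyl in place of hydrogen, three bonds along the chain from a carbonyl carbon, gives a number 53.6 percentage points lower from compound 3 to compound 4 (beyond the scatter), so a large fall from this one-carbon change is no longer a single case, though its size depends on the core that carries it: the same change on two cores in this assay, a number 71.7 percentage points lower (beyond the scatter) from compound 1 to compound 2 and a number 53.6 percentage points lower (beyond the scatter) from compound 3 to compound 4, 18.1 percentage points apart, beyond the scatter of two such steps

Ethyl in place of hydrogen likewise reads differently on two cores, with a number 11.5 percentage points higher from compound 2 to compound 4 (beyond the scatter) set against a step within the scatter on the shorter chain: the same change on two cores in this assay, a number 6.6 percentage points lower (within the scatter) from compound 1 to compound 3 and a number 11.5 percentage points higher (beyond the scatter) from compound 2 to compound 4, 18.1 percentage points apart, beyond the scatter of two such steps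

Propyl in place of hydrogen on the saturated chain carbon bound to a carbonyl carbon gives a number 60.2 percentage points lower from compound 1 to compound 4 (beyond the scatter), which places compound 4 with compound 2 in the low part of the series, and across these four compounds the numbers alternate high and low as the chain grows, with none going against that.

From the compounds shown here alone, whether the alternation holds for a longer chain, such as hexanoyl or heptanoyl on the same core, remains open, as does the effect of a branched chain such as isopropyl or a ring such as cyclopropyl at this position. Going by these compounds, all the numbers come from one concentration, so how they relate to potency also stays open.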